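The compounds below may be only part of what the source reports. "The series", "measured", "known", "first", "only" and "open" are said of these compounds alone.

Measured so far, in a functional assay on HepG2 cells (Homo sapiens) for antiproliferative activity, read by MTT assay; on this read-out lower numbers stand for stronger inhibition and higher numbers for weaker inhibition: compound 1 `CC1(C)CCc2c(ccc(C(=O)/C=C/c3ccc(OCc4cn(-c5ccc(Cl)cc5)nn4)cc3)c2O)O1` gives 102000 nM; compound 2 `Cc1ccc(-n2cc(COc3ccc(/C=C/C(=O)c4ccc5c(c4O)CCC(C)(C)O5)cc3)nn2)cc1Br` gives 110000 nM. Compound 2 and compound 1 give numbers that lie within the scatter of each other, so neither can be set apart from the other. The step of a 1.1-fold higher number from compound 1 to compound 2 (0.03 log units; within the scatter) is the only one measured, and it swaps one aromatic group for another on the same ring nitrogen.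

Compound 3 `CCCCCCCCn1cc(COc2ccc(/C=C/C(=O)c3ccc4c(c3O)CCC(C)(C)O4)cc2)nn1` differs from compound 2 in one place: octyl in place of 3-bromo-4-methylphenyl on an aromatic nitrogen. For the measured compounds named here, no measured step exchanges an aromatic group for a chain, so the single measured step gives little guidance here. With nothing pointing either way, the number for compound 3 is expected to stay close to that of compound 2, with the step of a 1.1-fold lower number from compound 2 to compound 3 (0.04 log units; within the scatter) as the expectation. Compound 3 is estimated at 100000 nM, within the range 30000 nM to 300000 nM.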

Compound 3, half-maximal inhibitory concentration: 74100 nM
Estimate against measurement, compound 3: 1.3-fold (0.13 log units) above; the measured number falls inside the stated range.
By their numbers in this assay, from the lowest: compounds 3, 1 and 2 (each within the scatter of the next).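

Swapping the aromatic ring on this ring nitrogen for an open octyl chain gives a 1.5-fold lower number from compound 2 to compound 3 (0.17 log units; within the scatter) in this assay, and a 1.4-fold lower number from compound 1 to compound 3 (0.14 log units; within the scatter) as well. So at this position, the earlier swap of one aromatic group for another and this swap of a ring for a chain both leave the number within the scatter. No supporting data offer an explanation for this result.

As far as these compounds go, whether any group on this nitrogen can move the number beyond the scatter stays open. A shorter chain such as butyl, an amine or a carboxylic acid could test this.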